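The compounds below may be only part of what the source reports. "The series", "measured", "known", "first", "only" and "open" are said of these compounds alone.

Compound 1 `CC(=O)N[C@@H]1CCC[C@H](C(=O)Nc2cc(-c3nnn4ccccc34)c(Cl)cn2)C1`: 2
Compound 2 `CC(=O)N[C@@H]1CCC[C@H](C(=O)Nc2cc(-c3cnn4c3CC(C)(C)C4)c(Cl)cn2)C1`: 3.8

In a physicochemical assay for lipophilicity, using the shake flask method, measured as octanol-water partition, at pH 7.4 (a higher number here means a more lipophilic compound, a lower number a more polar compound), compound 2 has the higher of the two measured numbers, at 3.8. Within the data shown here, the only measured step, a number 1.80 log units higher from compound 1 to compound 2 (beyond the scatter), is large, but it concerns a different group, on an aromatic carbon, and so offers no direct guide to the next change.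

Compound 3 `CC(=O)N[C@@H]1CC[C@H](C(=O)Nc2cc(-c3cnn4c3CC(C)(C)C4)c(Cl)cn2)C1` keeps that group of compound 2 and differs at the other end of the molecule: 3-acetamidocyclopentyl in place of 3-acetamidocyclohexyl on a carbonyl carbon, with 3-acetamidocyclopentyl in place of 3-acetamidocyclohexyl on a carbonyl carbon. Among the measured compounds shown here, no measured step covers this exchange. The expectation therefore starts from compound 2 at 3.8 and allows only a small downward move in this assay, not clearly beyond the scatter. The expected change is a number 0.30 log units lower from compound 2 to compound 3 (within the scatter). For compound 3 the estimate is 3.5, with an expected range from 3.1 to 3.9.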

Compound 3, distribution coefficient: 3.5
Beside the measured number, compound 3's estimate shows no gap at the digits printed, within the range that was stated.
By their numbers in this assay, from the lowest: compound 1; then compounds 3 and 2 (each within the scatter of the next).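

In this assay, the exchange on the carbonyl carbon now has a measured step of its own (a number 0.30 log units lower from compound 2 to compound 3 (within the scatter)). With the acetamido group kept, a five-membered ring of carbon only in place of a six-membered one does not separate the two compounds, whereas the exchange on the aromatic carbon gave a large step (a number 1.80 log units higher from compound 1 to compound 2 (beyond the scatter)). Nothing measured here accounts for either step.

The compounds shown leave open whether the same ring exchange would give a step of this size if the group on the aromatic carbon were that of compound 1. They also leave open how the number would respond to a larger change on the carbonyl carbon, such as a primary amine or a carboxylic acid in place of the acetamido group on the ring.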